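The source may report more compounds than this note shows. Statements on the series, on what has been measured and on what is new or still open speak of the compounds shown alone.

Values so far in a functional assay on the whole organism for inhibition, with Brassica rapa subsp. chinensis as the target, with a stated time of 3 days, tested at 100 ppm; a lower number here means less inhibition of growth, a higher number more inhibition of growth at the concentration tested

Compound 1 `CCCCCCCCCCNC(=O)/C=C/c1ccccc1` gives 15%
Compound 2 `CC(C)(C)NC(=O)/C=C/c1ccccc1` gives 73%
Compound 3 `CCCCCCCCNC(=O)/C=C/c1ccccc1` gives 42%

Compound 3 stands second highest of the three, with compound 1 lower and compound 2 higher, both gaps beyond the scatter. Compound 4 `CCCNC(=O)/C=C/c1ccccc1` differs from compound 3 by hydrogen in place of pentyl on a saturated chain carbon, three bonds along the chain from an amide-type nitrogen. Going by the values given here, the one measured step that bears on this is a number 27 percentage points higher from compound 1 to compound 3 (beyond the scatter), a modest rise on shortening the chain. One step is thin evidence, but this change removes more of the chain, so a further rise is expected in this assay. The expected step is a number 23 percentage points higher from compound 3 to compound 4 (beyond the scatter), upward. The estimate for compound 4 is 65%, within a range from 45% to 85%.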

Compound 4, percent growth inhibition at one concentration: 63%
Beside the measured number, compound 4's estimate is 2 percentage points above it, within the range that was stated.
By their numbers in this assay, from the lowest: compound 1; then compound 3; then compounds 4 and 2 (each within the scatter of the next).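

In this assay the rise on shortening the chain continues: hydrogen in place of pentyl gives a number 21 percentage points higher from compound 3 to compound 4 (beyond the scatter) and hydrogen in place of heptyl gives a number 48 percentage points higher from compound 1 to compound 4 (beyond the scatter) over the full span of chains. Propyl and tert-butyl on the amide-type nitrogen cannot be told apart, with a number 10 percentage points lower from compound 2 to compound 4 (within the scatter) for that swap, so a branched group is not needed for this level of inhibition. No measurement here explains the trend. Still open, as far as these compounds go, is whether an ethyl or methyl group on that nitrogen, or a cyclohexyl ring there, would hold this level of inhibition.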